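A few compounds are considered here, and "the series" means these few. Any claim that something is new, unique, unknown or untested is made for them only; others in the source may bear on it.

In a functional assay on UACC-62 cells (Homo sapiens) for inhibition, read by sulforhodamine B assay, with a stated time of 48 h, tested at 0.01 uM (a lower number here means a stronger effect, a higher number a weaker effect of the compound at the concentration tested), compound 1 `O=C(Nc1cccc(-n2cc(-c3ccncc3)c(-c3cc(O)cc(Cl)c3)n2)c1)Nc1ccc(Cl)c(Cl)c1` gives 96%, and compound 2 `COc1cc(Cl)cc(-c2nn(-c3cccc(NC(=O)Nc4ccc(Cl)c(C(F)(F)F)c4)c3)cc2-c2ccncc2)c1` gives 95%, numerically the lowest of the two numbers, though compound 1 sits within the scatter of it. Compound 3 `COc1cc(Cl)cc(-c2nn(-c3cccc(NC(=O)Nc4ccc(Cl)c(Cl)c4)c3)cc2-c2ccncc2)c1` has not yet been measured. It differs from compound 2 by chloro in place of trifluoromethyl on an aromatic carbon. Both measured compounds show only a weak effect, so the step from compound 2 to compound 3 is expected to be a number 1 percentage points higher from compound 2 to compound 3 (within the scatter) in this assay, nothing beyond the scatter. Compound 3 is therefore estimated to give 96%, within a range from 88% to 102%.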

Compound 3, a percentage reported as activity, at one concentration (the size of the read-out at that concentration, not a potency): 95%
The estimate for compound 3 lay 1 percentage points above the measured number; the range from low to high includes it.
By their numbers in this assay, from the lowest: compounds 2, 3 and 1 (each within the scatter of the next).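

In this assay chloro in place of trifluoromethyl on the aromatic carbon gives no change at the digits printed from compound 2 to compound 3 (within the scatter) and methyl in place of hydrogen on the oxygen gives a number 1 percentage points lower from compound 1 to compound 3 (within the scatter) so neither change separates these compounds at this concentration. All three compounds show only a weak effect here, so these steps say little about either position where the effect is larger. Nothing available bears on the reason for this result. Still open, from the compounds shown here alone, is whether an amine or a carboxylic acid in place of that chloro, or a longer chain in place of the methyl on the oxygen, would move the number beyond the scatter.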